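This account rests on a few compounds, and the source may have more. Where it says the series, first, only, none or still open, it means among the compounds named here.

Values in a functional assay on CCRF-CEM cells (Homo sapiens), read by MTT assay, with a stated time of 72 h; on this read-out lower numbers stand for stronger inhibition and higher numbers for weaker inhibition:

- Compound 1 (`Cc1nc(N)c2c(-c3ccccc3)cn([C@@H]3O[C@H](CO)[C@@H](O)[C@H]3O)c2n1`): > 20000 nM, a limit
- Compound 2 (`Nc1nc2c(c(-c3ccco3)cn2[C@@H]2O[C@H](CO)[C@@H](O)[C@H]2O)c(=O)[nH]1`): > 20000 nM, a limit
- Compound 3 (`Nc1nc2c(c(-c3ccoc3)cn2[C@@H]2O[C@H](CO)[C@@H](O)[C@H]2O)c(=O)[nH]1`): 17900 nM

Among these three, compound 3 alone gives an actual number, 17900 nM. The other two results are limits, and they coincide: the limit of > 20000 nM in this assay, at which 2 of the 3 values shown sit.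

The next compound to be tested, compound 4 (`Nc1nc2c(c(-c3cccs3)cn2[C@@H]2O[C@H](CO)[C@@H](O)[C@H]2O)c(=O)[nH]1`), carries thiophen-2-yl in place of furan-3-yl on an aromatic carbon of the shared core: thiophen-2-yl in place of furan-3-yl on an aromatic carbon.

For the measured compounds named here, only one measured step bears on this change, the exchange of furan-2-yl for furan-3-yl at the same place. That step is an at least 1.1-fold lower number from compound 2 to compound 3 (0.04 log units; that floor lies within the scatter). Going by the values given here, it offers a weak guide, since one of its two ends is a limit and no measured step involves thiophen-2-yl. Little movement is therefore expected in this assay, because the only exchange of one such ring for another gave an at least 1.1-fold lower number from compound 2 to compound 3 (0.04 log units; that floor lies within the scatter). The expected change is a 1.2-fold lower number from compound 3 to compound 4 (0.08 log units; within the scatter), which would not lie beyond the scatter. A result reported only as a limit would fit this expectation. For compound 4 the estimate is 15000 nM, with an expected range from 5000 nM to 30000 nM.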

Compound 4, half-maximal inhibitory concentration: > 20000 nM
Compound 4 ended at the assay's limit (the forecaster's own chance of this, stated with the estimate: 55%); at least 1.3-fold (0.12 log units) between middle value and limit.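

In this assay, thiophen-2-yl in place of furan-3-yl gives an at least 1.1-fold higher number from compound 3 to compound 4 (0.04 log units; that floor lies within the scatter), so this sulfur-bearing ring does not yield a measurable number at this place on the shared core. The step between furan-2-yl and thiophen-2-yl cannot be read, as compound 2 and compound 4 both end at a limit. Of the three five-membered rings shown at this place, only furan-3-yl in compound 3 gives an actual number, and the limit now holds most of the series: the limit of > 20000 nM in this assay, at which 3 of the 4 values shown sit.

As far as these compounds go, whether an amine, a short alkyl chain or a pyridine ring at this place would give a number clearly lower than that of compound 3 stays open. From the compounds shown here alone, the true size of any difference among the three five-membered rings also remains unknown.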